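Replacing pyrrolidin-1-yl with a silicon-bearing group

The source may hold more compounds than are shown below. What is called first, only, known or untested is meant among the compounds shown, and "the series" means these compounds.

Of the compounds shown here, three sharing one core have been tested in a functional assay on HL-60 cells (Homo sapiens) for antiproliferative activity, read by MTT assay, with a stated time of 48 h; a higher number here means a weaker inhibitor, a lower number a stronger inhibitor. Compound 1 `COC/C1=C/C[C@](C)(CCC=C(C)C)/C=C/[C@@H](OC(=O)C=C(C)C)[C@](C)(O)/C=C/C1=O`, carrying methoxy, gives 3070 nM. Compound 2 `CC(C)=CCC[C@]1(C)/C=C/[C@@H](OC(=O)C=C(C)C)[C@](C)(O)/C=C/C(=O)/C(CN(C(C)C)C(C)C)=C\C1`, carrying diisopropylamino, gives 740 nM. Compound 3 `CC(C)=CCC[C@]1(C)/C=C/[C@@H](OC(=O)C=C(C)C)[C@](C)(O)/C=C/C(=O)/C(CN2CCCC2)=C\C1`, carrying pyrrolidin-1-yl, gives 160 nM, the lowest number of the three and so the strongest inhibitor here.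

Compound 4 `CC[Si](CC)(CC)C/C1=C/C[C@](C)(CCC=C(C)C)/C=C/[C@@H](OC(=O)C=C(C)C)[C@](C)(O)/C=C/C1=O` is still unmeasured and differs from compound 3 by a group of 7 heavy atoms (6 carbon, 1 silicon; no ring) in place of a group of 5 heavy atoms (4 carbon, 1 nitrogen; one five-membered non-aromatic ring with 1 hetero atom), on a saturated chain carbon bound to a double-bonded ring carbon. The swap sits on a saturated chain carbon bound to a double-bonded ring carbon, the place where all three measured compounds differ. Replacing methoxy with diisopropylamino gave a 4.1-fold lower number from compound 1 to compound 2 (0.62 log units; beyond the scatter), and replacing methoxy with pyrrolidin-1-yl gave a 19-fold lower number from compound 1 to compound 3 (1.28 log units; beyond the scatter). Changing diisopropylamino to pyrrolidin-1-yl gave a 4.6-fold lower number from compound 2 to compound 3 (0.67 log units; beyond the scatter).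

Going by the values given here, the entering group holds no nitrogen, and the one measured compound without nitrogen in that place is compound 1, at 3070 nM. A large rise in this assay is therefore expected, estimated as a 13-fold higher number from compound 3 to compound 4 (1.10 log units; beyond the scatter). Compound 4 is expected to give 2000 nM, with an estimated range of 600 nM to 7000 nM.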

Compound 4, half-maximal inhibitory concentration: 2810 nM
Beside the measured number, compound 4's estimate is 1.4-fold (0.15 log units) below it; measured number inside the range.
By their numbers in this assay, from the lowest: compound 3; then compound 2; then compounds 4 and 1 (each within the scatter of the next).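

In this assay, the silicon-bearing group falls well behind pyrrolidin-1-yl (an 18-fold higher number from compound 3 to compound 4 (1.24 log units; beyond the scatter)) and also behind diisopropylamino (a 3.8-fold higher number from compound 2 to compound 4 (0.58 log units; beyond the scatter)), even though diisopropylamino has the same count of 7 heavy atoms and likewise no ring. Against methoxy, a far smaller group that also lacks nitrogen, the step stays within the scatter (a 1.1-fold lower number from compound 1 to compound 4 (0.04 log units; within the scatter)), so among the compounds shown, both groups with nitrogen give lower numbers than both groups without it, and group size alone does not separate them. Nothing measured here explains this difference.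

From the compounds shown here alone, whether nitrogen itself drives the gap remains open, as does the role of silicon, which an all-carbon group such as 2,2-dimethylpropyl could help separate. Piperidin-1-yl or morpholin-4-yl would show how far the ring of pyrrolidin-1-yl can be changed at this place.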